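The source may hold more compounds than are shown below. What is called first, only, known or untested is meant among the compounds shown, and "the series" means these compounds.

Compound 1, with the structure `COc1ccc(C(=O)/C=C/c2ccc(OC)c(Br)c2)c(O)c1`, and compound 3, with the structure `COc1cc(O)ccc1C(=O)/C=C/c1ccc(F)cc1`, share the same core arrangement but differ in more than one place, and the difference between the two cores is not broken down here. In a functional assay on SNU-638 cells (Homo sapiens) for cytotoxicity, read by MTT assay (a lower number here means a stronger inhibitor, a higher number a weaker inhibitor), compound 1 has "not determined" (no result reported). Compound 3 reaches only a limit of the assay, at > 25000 nM, which is the limit (the limit of > 25000 nM in this assay, at which 1 of the 3 values shown sits). Compound 2, with the structure `O=C(/C=C/c1ccc(F)cc1)c1ccc(O)cc1O`, arises from compound 3 by the change (hydrogen in place of methyl on an oxygen on an aromatic ring); in this assay compound 2 gives 9430 nM, so the step is an at least 2.6-fold lower number from compound 3 to compound 2 (0.42 log units; beyond the scatter). Compound 4, with the structure `COc1ccc(/C=C/C(=O)c2ccc(O)cc2O)cc1Br`, arises from compound 1 by the same change, (hydrogen in place of methyl on an oxygen on an aromatic ring), at the same kind of place. With no number for compound 1, the expectation for compound 4 rests on compound 2 and on the step from compound 3 to compound 2, an at least 2.6-fold lower number from compound 3 to compound 2 (0.42 log units; beyond the scatter), which favours the hydroxy form. Compound 4 is therefore expected to fall near 8000 nM, with a range from 2500 nM to 25000 nM.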

Compound 4, half-maximal inhibitory concentration: 2890 nM
Estimate against measurement, compound 4: 2.8-fold (0.44 log units) above; the measured number falls inside the stated range.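

Within the data shown here, compound 1 has no single number in this assay, so the step from compound 1 to compound 4 cannot be read, and the result for compound 4 adds no new step. Among these compounds, the one readable step for methoxy to hydroxy is an at least 2.6-fold lower number from compound 3 to compound 2 (0.42 log units; beyond the scatter). The compounds shown leave open whether methoxy to hydroxy acts in the same way between compound 1 and compound 4.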